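Compound 2 to compound 4: hydroxy for chloro

The source may hold more compounds than are shown below. What is called first, only, known or untested is meant among the compounds shown, and "the series" means these compounds.

Within the data shown here, in a functional assay on SW480 cells (Homo sapiens) for cytotoxicity, read by MTT assay, with a stated time of 72 h (a lower number here means a stronger inhibitor of growth, a higher number a weaker inhibitor of growth), compound 2 (`N#C/C(=C/c1ccc(Cl)cc1)C(=O)c1ccc[nH]1`) gives 68000 nM as the only actual number. Compound 1 (`N#C/C(=C/c1ccc2ccccc2c1)C(=O)c1ccc[nH]1`) gives only a limit (< 10000 nM). Compound 3 (`N#C/C(=C/c1ccc(Cl)c(Cl)c1)C(=O)c1ccc[nH]1`) also gives only a limit (< 10000 nM). Compound 4 (`N#C/C(=C/c1ccc(O)cc1)C(=O)c1ccc[nH]1`) carries hydroxy in place of chloro on an aromatic carbon, para to a large group (hydroxy in place of chloro on an aromatic carbon). Among the measured compounds shown here, the only measured step, an at least 6.8-fold lower number from compound 2 to compound 3 (0.83 log units; beyond the scatter), is a different change, chloro in place of hydrogen on an aromatic carbon, so it shows that the number can move but sets no direction here. In this assay the expected change is small and within the scatter, an estimated 1.4-fold lower number from compound 2 to compound 4 (0.13 log units; within the scatter) as the working figure. The estimate for compound 4 is 50000 nM with an expected range from 10000 nM to 200000 nM as a wide allowance.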

Compound 4, concentration for 50% growth inhibition: < 10000 nM
Compound 4: no number, only a limit; the forecaster's own chance of this, stated with the estimate: 25%; middle value at least 5.0-fold (0.69 log units) from the limit.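

In this assay, replacing the chloro itself, on an aromatic carbon para to a large group, gives an at least 6.8-fold lower number from compound 2 to compound 4 (0.83 log units; beyond the scatter). The earlier step kept this chloro, whereas this one removes it and the number still falls, so chloro is not required at this position for the lower number. The value of compound 4 is a limit, so this step gives a bound and not a size, and the same kind of limit recurs across the series: the limit of < 10000 nM in this assay, at which 3 of the 4 values shown sit.

From the compounds shown here alone, how far compound 4 lies past its limit remains open. So does the effect of an amine, a methoxy group or a carboxylic acid at this position.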